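The source may report more compounds than this note shows. Statements on the series, on what has been measured and on what is new or still open speak of the compounds shown alone.

Of the compounds shown here, three sharing one core have been measured so far in a functional assay on Ishikawa cells (Homo sapiens) for antiproliferative activity, read by CCK-8 assay, with a stated time of 48 h (a lower number here means a stronger inhibitor, a higher number a weaker inhibitor), on this series. Compound 1 (`CNC(=O)/C=C/CN1CC(Oc2ccc(Oc3c(-c4ccc(F)cc4)sc4cc(O)ccc34)cc2)C1`) gives > 25000 nM as its reading, and this is a limit of the assay, not a number. Compound 2 (`O=C(/C=C/CN1CC(Oc2ccc(Oc3c(-c4ccc(F)cc4)sc4cc(O)ccc34)cc2)C1)N1CCC1`) gives 5450 nM and compound 3 (`O=C(/C=C/CNCCOc1ccc(Oc2c(-c3ccc(F)cc3)sc3cc(O)ccc23)cc1)N1CCC1`) gives 6560 nM in the same test, so these two values stand within the scatter of each other. Compound 4 (`C=C(C)C(=O)N1CC(Oc2ccc(Oc3c(-c4ccc(F)cc4)sc4cc(O)ccc34)cc2)C1`) has not yet been measured. Its difference from compound 3 is 1-((1-methylethenyl)carbonyl)azetidin-3-yl in place of 2-((3-((azetidin-1-yl)carbonyl)prop-2-en-1-yl)amino)ethyl on an oxygen on an aromatic ring in count, and in words 1-((1-methylethenyl)carbonyl)azetidin-3-yl sits in place of 2-((3-((azetidin-1-yl)carbonyl)prop-2-en-1-yl)amino)ethyl on an oxygen on an aromatic ring. Among the compounds with values here, two measured steps bear on this change, and both start from a limit: an at least 4.5-fold lower number from compound 1 to compound 2 (0.66 log units; beyond the scatter) with the amide exchange, and an at least 3.8-fold lower number from compound 1 to compound 3 (0.58 log units; beyond the scatter) with a new chain on the oxygen. Neither brings in the group that enters compound 4, so they set no size for this change, and no step beyond the scatter is expected in either direction. The expected move is a 1.2-fold higher number from compound 3 to compound 4 (0.09 log units; within the scatter) as estimated here, with much uncertainty. For compound 4 the estimated value is 8000 nM in this assay with an expected range from 2500 nM to 25000 nM as its upper end.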

Compound 4, half-maximal inhibitory concentration: 14200 nM
The estimate for compound 4 lay 1.8-fold (0.25 log units) below the measured number; the measured number falls inside the stated range.
By their numbers in this assay, from the lowest: compounds 2 and 3 (each within the scatter of the next); then compound 4. At a limit, above all of these: compound 1.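

In this assay, the group on the oxygen on an aromatic ring matters on the upper side of the series: a 2.2-fold higher number from compound 3 to compound 4 (0.34 log units; beyond the scatter), and on the amine nitrogen in the ring a 2.6-fold higher number from compound 2 to compound 4 (0.42 log units; beyond the scatter). Within the data shown here, until now, the only changes with a readable effect had started from a limit, so this is the first pair of steps with a measured size at both ends, and both point the same way: 1-((1-methylethenyl)carbonyl)azetidin-3-yl, with its carbonyl placed directly on the ring nitrogen, reads weaker than either chain that carries the azetidin-1-yl amide. The third step gives only a floor (an at least 1.7-fold lower number from compound 1 to compound 4 (0.24 log units; that floor lies within the scatter)). Its size cannot be read, since the reading of compound 1 is a limit of the assay and not a number: the limit of > 25000 nM in this assay, at which 1 of the 4 values shown sits.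

The compounds shown do not separate the two parts of the exchange, the loss of the azetidin-1-yl amide and the shift of the carbonyl onto the ring nitrogen, since both change together. On these data alone, it also stays open how a plain prop-2-enoyl or a saturated propanoyl on that ring nitrogen, or a piperidin-1-yl amide on the longer chain, would read.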